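A few compounds are considered here, and "the series" means these few. Any claim that something is new, unique, unknown or untested is made for them only; others in the source may bear on it.

Series summary in a functional assay on HT-29 cells (Homo sapiens) for cytotoxicity, read by MTT assay, with a stated time of 72 h; on this read-out lower numbers stand for stronger inhibition of growth and higher numbers for weaker inhibition of growth:
compound 1, `CCCOC(=O)Nc1ccc([Se]C#N)cc1`, gives 51900 nM
compound 2, `CCCCOC(=O)Nc1ccc([Se]C#N)cc1`, gives 31300 nM
compound 3, `CC(C)COC(=O)Nc1ccc([Se]C#N)cc1`, gives 31300 nM

Compound 3 stands level with compound 2 at the digits given, the two together the lowest of the three numbers; a 1.7-fold lower number from compound 1 to compound 3 (0.22 log units; within the scatter) is within the scatter, as is a 1.7-fold lower number from compound 1 to compound 2 (0.22 log units; within the scatter), and no change at the digits printed from compound 2 to compound 3 (within the scatter) is no change. Across these three, the chain on the oxygen next to the carbonyl group, whether propyl, butyl or isobutyl, leaves the number where it is.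

Compound 4, `C=CCOC(=O)Nc1ccc([Se]C#N)cc1`, is not yet measured. Its change from compound 3 is vinyl in place of isopropyl on a saturated chain carbon bound to an oxygen next to a carbonyl group; cut one bond further out this reads isobutyl to allyl, isobutoxy to allyloxy. Among the compounds with values here, the steps that bear on it are no change at the digits printed from compound 2 to compound 3 (within the scatter) and a 1.7-fold lower number from compound 1 to compound 3 (0.22 log units; within the scatter), both within the scatter, and both concern only the size and shape of this chain. Within the data shown here, no measured step introduces a double bond outside aromatic rings, so the vinyl group itself is untested here. The expected step of a 1.3-fold higher number from compound 3 to compound 4 (0.11 log units; within the scatter) is none beyond the scatter, set slightly toward compound 1 because 51900 nM belongs to the shortest of the measured chains. Compound 4 is estimated at 40000 nM, with a range from 15000 nM to 100000 nM.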

Compound 4, concentration for total growth inhibition: 48600 nM
Compound 4: middle estimate off by 1.2-fold (0.08 log units), on the low side, and the stated range covers the measured number.
By their numbers in this assay, from the lowest: compounds 2, 3, 4 and 1 (each within the scatter of the next).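

With vinyl in place of isopropyl or propyl on the saturated chain carbon bound to an oxygen next to a carbonyl group, the first double bond outside aromatic rings at this position gives in this assay both a 1.6-fold higher number from compound 3 to compound 4 (0.19 log units; within the scatter) and a 1.6-fold higher number from compound 2 to compound 4 (0.19 log units; within the scatter) and so moves the number no further than the scatter. Vinyl in place of ethyl gives a 1.1-fold lower number from compound 1 to compound 4 (0.03 log units; within the scatter) and is likewise no step beyond the scatter, so this position has now taken a double bond as well as a change in chain length and branching without any of the four compounds separating from the next. No measurement at hand accounts for any of these steps or says what the double bond does here.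

As far as these compounds go, all four chains hold carbon and hydrogen only, so it remains open whether a terminal amine, a carboxylic acid, a phenyl ring or a much longer chain at this position would produce a step beyond the scatter. The shared core is the same throughout, so these compounds say nothing about how much of the number depends on it.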